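The compounds below may be only part of what the source reports. "The series", "measured", "known", "first", "only" and "open" are said of these compounds alone.

Compound 2 `O=C1NC(=O)/C(=C/c2ccc(C(=O)NC[C@@H]3C[C@@H](Oc4ccccc4-c4ccccc4)CN3C(=O)c3ccccc3C(=O)c3ccc(F)cc3)cc2)S1` and compound 1 `CC(C)Cc1cccc(Br)c1O[C@@H]1C[C@@H](CNC(=O)c2ccc(/C=C3\SC(=O)NC3=O)cc2)N(C(=O)c2ccccc2C(=O)c2ccc(F)cc2)C1` share one core and differ at the oxygen on a saturated carbon, where compound 2 carries 2-phenylphenyl and compound 1 carries 2-bromo-6-isobutylphenyl. In a functional assay on THP-1 cells (Homo sapiens) for inhibition (on this read-out higher numbers stand for weaker inhibition and lower numbers for stronger inhibition), compound 2 gives 310 nM, and compound 1 gives 300 nM. The step between them is a 1.0-fold higher number from compound 1 to compound 2 (0.01 log units; within the scatter), so the two compounds cannot be told apart on this read-out, and compound 2 stands level with compound 1 rather than apart from it.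

Compound 3 `O=C1NC(=S)S/C1=C\c1ccc(C(=O)NC[C@@H]2C[C@@H](Oc3ccccc3-c3ccccc3)CN2C(=O)c2ccccc2C(=O)c2ccc(F)cc2)cc1` keeps everything of compound 2 except (a group of 8 heavy atoms (4 carbon, 1 nitrogen, 1 oxygen, 2 sulfur; one five-membered non-aromatic ring with 2 hetero atoms) in place of a group of 8 heavy atoms (4 carbon, 1 nitrogen, 2 oxygen, 1 sulfur; one five-membered non-aromatic ring with 2 hetero atoms), on an aromatic carbon). Among the measured compounds shown here, no measured step touches this part of the molecule: the only step available, a 1.0-fold higher number from compound 1 to compound 2 (0.01 log units; within the scatter), changes the group on the oxygen on a saturated carbon and leaves the five-membered ring untouched, so it gives no guide to the size or direction of the present change. With nothing to anchor a shift, the expectation in this assay is for no step beyond the scatter, a 1.0-fold lower number from compound 2 to compound 3 (0.01 log units; within the scatter). Compound 3 is therefore estimated at 300 nM, with a range from 100 nM to 900 nM.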

Compound 3, half-maximal inhibitory concentration: 660 nM
Compound 3: middle estimate off by 2.2-fold (0.34 log units), on the low side, and the stated range covers the measured number.
By their numbers in this assay, from the lowest: compounds 1 and 2 (each within the scatter of the next); then compound 3.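

Unlike the exchange on the oxygen, which stayed within the scatter, the exchange of the five-membered ring group on the aromatic carbon, para to a large group, moves the read-out: in this assay the result is a 2.1-fold higher number from compound 2 to compound 3 (0.33 log units; beyond the scatter), modest in size but beyond the scatter. The two groups match in heavy atoms, double bonds outside aromatic rings, hydrogen-bond donors and acceptors, and net charge, and differ in that one oxygen gives way to a sulfur, so even this small exchange of atoms is enough to weaken inhibition at this position. Nothing available accounts for the shift.

Among the compounds shown here, with only one pair bearing on this position, it remains open whether the same exchange would give a step of similar size and direction with the 2-bromo-6-isobutylphenyl group of compound 1 on the oxygen. Also open, as far as these compounds go, is how the read-out would respond if a carboxylic acid or an amine stood on the aromatic carbon in place of the five-membered ring group.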